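Sulfonyl for carbonyl on the urea-side nitrogen of the biaryl series

A few compounds are considered here, and "the series" means these few. Any claim that something is new, unique, unknown or untested is made for them only; others in the source may bear on it.

Measured compounds in a functional assay on HEK293 cells for agonist activity at Motilin receptor (Homo sapiens), read by FLIPR and calcium flux; on this read-out higher numbers stand for an effect only at larger amounts of compound and lower numbers for an effect already at smaller amounts:
compound 1 `COCCCN(Cc1ccccc1-c1ccc(CN2CCNCC2)cc1)C(=O)NC1CCCCC1`, 501 nM
compound 2 `COCCCN(Cc1ccccc1-c1ccc(CN2CCNCC2)cc1)C(=O)COc1ccccc1`, 398 nM

Compound 2 holds the lower of the two numbers in this assay, but the step of a 1.3-fold lower number from compound 1 to compound 2 (0.10 log units; within the scatter) is within the scatter, so the two compounds cannot be ordered. Compound 3 `COCCCN(Cc1ccccc1-c1ccc(CN2CCNCC2)cc1)S(=O)(=O)c1ccc(F)cc1` is not yet measured. It differs from compound 2 by (4-fluorophenyl)sulfonyl in place of (phenoxymethyl)carbonyl on an amine nitrogen. For the measured compounds named here, the only measured step, a 1.3-fold lower number from compound 1 to compound 2 (0.10 log units; within the scatter), exchanges one carbonyl substituent for another on the same amine nitrogen and is within the scatter; it does not touch the carbonyl itself. Going by the values given here, no measured pair bears on replacing a carbonyl by a sulfonyl, so the step to compound 3 in this assay is uncertain in size and direction. Taking the flat step from compound 1 to compound 2 as the only guide, compound 3 is expected to give about 630 nM in this assay, within 200 nM to 2000 nM. This estimate means a step of a 1.6-fold higher number from compound 2 to compound 3 (0.20 log units; within the scatter), expected to be at most modest.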

Compound 3, half-maximal effective concentration: 631 nM
The estimate for compound 3 lay 1.0-fold (0.00 log units) below the measured number; measured number inside the range.
By their numbers in this assay, from the lowest: compounds 2, 1 and 3 (each within the scatter of the next).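

In this assay, a sulfonyl link on this amine nitrogen is not separated from either carbonyl-linked group: the readings are a 1.6-fold higher number from compound 2 to compound 3 (0.20 log units; within the scatter) and a 1.3-fold higher number from compound 1 to compound 3 (0.10 log units; within the scatter). The earlier pair changed only the group on the carbonyl, whereas these steps replace the carbonyl as well and still stay within the scatter. No evidence on the origin of this flat result is available.

On these data alone, each step changes the link and the group on it together, so the contribution of the sulfonyl alone stays unresolved, and it is open whether a sulfonyl bearing methyl or unsubstituted phenyl would read like (4-fluorophenyl)sulfonyl. As far as these compounds go, all three compounds share the rest of the core of compound 1, so the effect of a change elsewhere, such as a carboxylic acid on the core, also stays open.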